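Exchanging the Group on Sulfur in Compound 3

This account rests on a few compounds, and the source may have more. Where it says the series, first, only, none or still open, it means among the compounds named here.

Three compounds measured so far in a functional assay on PC-3 cells (Homo sapiens) for antiproliferative activity, read by MTT assay, with a stated time of 48 h; a higher number here means a weaker inhibitor, a lower number a stronger inhibitor
- Compound 1 `COc1ccc(CN(C(=O)CSc2nc3ccc(OC)cc3s2)c2cc(OC)c(OC)c(OC)c2)cc1` gives 20200 nM
- Compound 2 `COc1ccc(CN(C(=O)CCSc2nc3ccccc3o2)c2cc(OC)c(OC)c(OC)c2)cc1` gives 20200 nM
- Compound 3 `COc1ccc(CN(C(=O)CSc2nc3ccccc3[nH]2)c2cc(OC)c(OC)c(OC)c2)cc1` gives 14400 nM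

Compound 3 stands level with the other two. The steps that reach it are a 1.4-fold lower number from compound 1 to compound 3 (0.15 log units; within the scatter) and a 1.4-fold lower number from compound 2 to compound 3 (0.15 log units; within the scatter) and neither is a real difference. Compound 4 `COc1ccc(CN(C(=O)CSc2nc3ccccc3o2)c2cc(OC)c(OC)c(OC)c2)cc1` carries 1,3-benzoxazol-2-yl in place of 1H-benzimidazol-2-yl on a sulfur and is otherwise the same. Both steps above changed this group, and no change at the digits printed from compound 1 to compound 2 (within the scatter) also changed it, yet all three stayed small. No step beyond the scatter is therefore expected in this assay, and no clear direction either. The step expected is a 1.2-fold higher number from compound 3 to compound 4 (0.07 log units; within the scatter) and nothing larger. For compound 4 the estimate is 17000 nM as the expected value, with 8000 nM to 36000 nM as its expected range.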

Compound 4, half-maximal inhibitory concentration: 3530 nM
Estimate against measurement, compound 4: 4.8-fold (0.68 log units) above; measured number below the stated range.
By their numbers in this assay, from the lowest: compound 4; then compounds 3, 1 and 2 (each within the scatter of the next).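

In this assay, going by these compounds alone, the group on this sulfur does matter: 1,3-benzoxazol-2-yl in place of 1H-benzimidazol-2-yl gives a 4.1-fold lower number from compound 3 to compound 4 (0.61 log units; beyond the scatter) and is the first step here beyond the scatter. The same group in place of 6-methoxy-1,3-benzothiazol-2-yl gives a 5.7-fold lower number from compound 1 to compound 4 (0.76 log units; beyond the scatter) and (1,3-benzoxazol-2-yl)sulfanyl in place of ((1,3-benzoxazol-2-yl)sulfanyl)methyl gives a 5.7-fold lower number from compound 2 to compound 4 (0.76 log units; beyond the scatter) so the chain on the carbonyl carbon counts as well. No measurement here accounts for these steps.

As far as these compounds go, whether 1,3-benzothiazol-2-yl without its methoxy, or 1-methylbenzimidazol-2-yl, would match compound 4 stays open. So does whether a still longer chain follows compound 2.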